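Series notes: thiophen-2-yl replaced by 2,6-dichlorophenyl

The compounds below may be only part of what the source reports. "The series", "measured", "known", "first", "only" and "open" are said of these compounds alone.

The set shares one core and varies the group on an aromatic carbon next to the ring nitrogen. Compound 1 `CCOC(=O)c1cc([Se]c2ccccc2)c2cc(OC)ccc2n1` carries ethoxycarbonyl there, and in a functional assay on SK-MEL-147 cells (Homo sapiens) for cytotoxicity, read by MTT assay, with a stated time of 24 h (on this read-out lower numbers stand for an effect already at smaller amounts and higher numbers for an effect only at larger amounts of compound), compound 1 gives 33000 nM. Compound 2 `COc1ccc2nc(-c3c(C)cccc3C)cc([Se]c3ccccc3)c2c1` carries 2,6-dimethylphenyl and in this assay compound 2 gives 37300 nM; the step of a 1.1-fold higher number from compound 1 to compound 2 (0.05 log units; within the scatter) is within the scatter. Compound 3 `COc1ccc2nc(-c3cccs3)cc([Se]c3ccccc3)c2c1` carries thiophen-2-yl. In this assay compound 3 reaches only the limit of the assay, > 150000 nM, a bound and not a number (the limit of > 150000 nM in this assay, at which 1 of the 3 values shown sits). The steps of an at least 4.5-fold higher number from compound 1 to compound 3 (0.65 log units; beyond the scatter) and an at least 4.0-fold higher number from compound 2 to compound 3 (0.60 log units; beyond the scatter) both lie beyond the scatter, so compound 3 stands at the weak end of what has been measured.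

Compound 4 `COc1ccc2nc(-c3c(Cl)cccc3Cl)cc([Se]c3ccccc3)c2c1` is not yet measured. Its change from compound 3 is 2,6-dichlorophenyl in place of thiophen-2-yl on an aromatic carbon. The step that bears on it is an at least 4.0-fold higher number from compound 2 to compound 3 (0.60 log units; beyond the scatter), which runs in the opposite direction: a 2,6-disubstituted phenyl giving way to thiophen-2-yl cost potency beyond the scatter. Compound 4 restores a 2,6-disubstituted phenyl, with chlorine in place of methyl, and the expectation is therefore a return toward the level of compound 2, a downward step in number, an at least 3.7-fold lower number from compound 3 to compound 4 (0.57 log units; beyond the scatter). Within the data shown here, no measured pair shows whether chlorine and methyl behave alike here, so the range is kept wide. Compound 4 is thus expected to give 40000 nM in this assay, between 15000 nM and 150000 nM.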

Compound 4, half-maximal effective concentration: > 150000 nM
Compound 4: only a limit was reported; the forecaster's own chance of this, stated with the estimate: 20%; middle value at least 3.7-fold (0.57 log units) away from the limit.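

In this assay compound 4 reaches only a limit, > 150000 nM, a bound and not a number, and the step between compound 3 and compound 4 cannot be read. The other two steps can: 2,6-dichlorophenyl in place of 2,6-dimethylphenyl gives an at least 4.0-fold higher number from compound 2 to compound 4 (0.60 log units; beyond the scatter), and in place of ethoxycarbonyl it gives an at least 4.5-fold higher number from compound 1 to compound 4 (0.65 log units; beyond the scatter), so this position separates two phenyl groups substituted at the same places, something compound 2 alone could not show. Among the groups shown, a reported number at this position is confined to ethoxycarbonyl and 2,6-dimethylphenyl, while thiophen-2-yl and 2,6-dichlorophenyl both end at the limit, and how far compound 3 and compound 4 lie beyond it stays unknown: the limit of > 150000 nM in this assay, at which 2 of the 4 values shown sit.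

Open, as far as these compounds go, is whether the gap between 2,6-dimethylphenyl and 2,6-dichlorophenyl follows from methyl and chlorine as such, which unsubstituted phenyl or a phenyl with a single methyl at this place would help to settle. Also open, from the compounds shown here alone, is whether an amine, a carboxylic acid or a longer alkyl chain here would give a number clearly lower than those of compound 1 and compound 2.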